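Working notes: replacing 1-bromoethyl on the carbonyl carbon

The compounds below may be only part of what the source reports. "The series", "measured", "known", "first", "only" and "open" are said of these compounds alone.

Measured in a functional assay on KYSE-450 cells (Homo sapiens) for inhibition, read by MTT assay, with a stated time of 48 h; a higher number here means a weaker inhibitor, a lower number a stronger inhibitor:
- compound 1 `CCCCC(=O)N(Cc1ccc(OC)c(O)c1)c1cc(OC)c(OC)c(OC)c1`: 300 nM
- compound 2 `COc1ccc(CN(C(C)=O)c2cc(OC)c(OC)c(OC)c2)cc1O`: 160 nM
- compound 3 `COc1ccc(CN(C(=O)C(C)Br)c2cc(OC)c(OC)c(OC)c2)cc1O`: 160 nM

Compound 3 stands level with compound 2 at the digits shown, and all three values lie within the scatter of one another. The next structure is compound 4 `COc1ccc(CN(C(=O)C=C(C)C)c2cc(OC)c(OC)c(OC)c2)cc1O`, with 2-methylprop-1-en-1-yl in place of 1-bromoethyl on a carbonyl carbon. Among the compounds with values here, no measured compound carries this group, so the evidence is indirect.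

Three measured steps change the group at this same place. They are no change at the digits printed from compound 2 to compound 3 (within the scatter), a 1.9-fold lower number from compound 1 to compound 3 (0.27 log units; within the scatter) and a 1.9-fold lower number from compound 1 to compound 2 (0.27 log units; within the scatter). None of these exceeds the scatter, so methyl, butyl and 1-bromoethyl at this place give no measurable separation in this assay. On that basis, no step beyond the scatter is expected in this assay. The expected step is a 1.3-fold higher number from compound 3 to compound 4 (0.10 log units; within the scatter). For compound 4, the estimated value is 200 nM, with an estimated range of 80 nM to 500 nM.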

Compound 4, half-maximal inhibitory concentration: 280 nM
Estimate against measurement, compound 4: 1.4-fold (0.15 log units) below, and the stated range covers the measured number.
By their numbers in this assay, from the lowest: compounds 2, 3, 4 and 1 (each within the scatter of the next).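

In this assay, within the data shown here, 2-methylprop-1-en-1-yl on this carbonyl carbon, the only group of the four with a double bond outside aromatic rings, gives no separation from the other three: there is a 1.8-fold higher number from compound 3 to compound 4 (0.24 log units; within the scatter) and a 1.8-fold higher number from compound 2 to compound 4 (0.24 log units; within the scatter) and a 1.1-fold lower number from compound 1 to compound 4 (0.03 log units; within the scatter). Methyl, butyl, 1-bromoethyl and 2-methylprop-1-en-1-yl therefore all fall within the scatter at this place, so neither this double bond nor the exchange of 1-bromoethyl for an all-carbon group of this kind registers as a separate step in this set. Nothing available accounts for these small steps.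

The compounds shown leave open whether any group at this place can move the number beyond the scatter. A phenyl ring, an amine or a carboxylic acid on this carbonyl carbon would test that.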